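Fluoro in place of hydrogen on compound 3

The source may hold more compounds than are shown below. What is called first, only, known or untested is meant among the compounds shown, and "the series" means these compounds.

Measured so far in an ADME assay on MCF-10A cells (Homo sapiens) for cytotoxicity, read by MTT assay, with a stated time of 48 h (a higher number here means a weaker inhibitor, a lower number a stronger inhibitor), as follows:
- compound 1 `COc1cc(C#N)ccc1OCc1nnc(-c2ccc(Cl)cc2)o1` gives 89500 nM
- compound 2 `N#Cc1ccc(OCc2nnc(-c3ccc(F)cc3)o2)cc1F` gives 84200 nM
- compound 3 `c1ccc(-c2nnc(COc3ccc(-c4nnco4)cc3)o2)cc1` gives > 100000 nM as a limit, not a number

Compound 3 stands only at a limit, and no number is known for it: the limit of > 100000 nM in this assay, at which 1 of the 3 values shown sits.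

Compound 4 `Fc1ccc(-c2nnc(COc3ccc(-c4nnco4)cc3)o2)cc1` differs from compound 3 by a single change fluoro in place of hydrogen on an aromatic carbon which reads as phenyl to 4-fluorophenyl. Among the measured compounds shown here, no measured pair shows this change on its own, so the expectation rests on thin ground. Compound 2 also carries the 4-fluorophenyl group and gives 84200 nM on a different remainder of the structure. Compound 1 gives 89500 nM in the same range as that value. A small shift toward lower numbers is expected, close to the scatter, and the estimated size is an at least 1.1-fold lower number from compound 3 to compound 4 (0.04 log units; that floor lies within the scatter) for this change. For compound 4 the expected value is 90000 nM with an estimated range from 50000 nM to 130000 nM in this assay and a report of only a limit would not be surprising.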

Compound 4, half-maximal inhibitory concentration: > 100000 nM
Compound 4 ended at the assay's limit; the forecaster's own chance of this, stated with the estimate: 45%; at least 1.1-fold (0.04 log units) between middle value and limit.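

In this assay, among the compounds shown here, compound 4 gives > 100000 nM, a limit and not a number, and compound 3 stands at the same limit, so no step between compound 3 and compound 4 can be read: the limit of > 100000 nM in this assay, at which 2 of the 4 values shown sit. The compounds shown leave open what phenyl to 4-fluorophenyl does to the value in this assay.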